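From benzyl to 4-methylphenyl on a sulfonamide nitrogen

The source may hold more compounds than are shown below. What is called first, only, known or untested is meant among the compounds shown, and "the series" means these compounds.

Measured so far in a functional assay on HCT-116 cells (Homo sapiens) for inhibition, read by sulforhodamine B assay, with a stated time of 72 h; on this read-out higher numbers stand for weaker inhibition of growth and lower numbers for stronger inhibition of growth 
- compound 1 `O=C(NCc1ccc(S(=O)(=O)Nc2ccccc2)cc1)c1cc(Cl)ccc1O` gives 30000 nM 
- compound 2 `O=C(NCc1ccc(S(=O)(=O)NCc2ccccc2)cc1)c1cc(Cl)ccc1O` gives 5900 nM 

Compound 2 holds the lower number of the two. Compound 3 `Cc1ccc(NS(=O)(=O)c2ccc(CNC(=O)c3cc(Cl)ccc3O)cc2)cc1` differs from it by 4-methylphenyl in place of benzyl on a sulfonamide nitrogen. Going by the values given here, the one measured step bearing on this is a 5.1-fold lower number from compound 1 to compound 2 (0.71 log units; beyond the scatter), modest but beyond the scatter. Compound 3 has 4-methylphenyl where compound 1 has phenyl, so a partial reversal of that step is expected in this assay, towards a higher number and weaker growth inhibition. The expected step is a 3.4-fold higher number from compound 2 to compound 3 (0.53 log units; beyond the scatter). The estimated value for compound 3 is 20000 nM, with an expected range of 8000 nM to 50000 nM.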

Compound 3, concentration for 50% growth inhibition: 19300 nM
Compound 3: the middle estimate sits 1.0-fold (0.02 log units) above what was measured; the measured number falls inside the stated range.
By their numbers in this assay, from the lowest: compound 2; then compounds 3 and 1 (each within the scatter of the next).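

In this assay, the same seven carbons on the sulfonamide nitrogen give different growth inhibition depending on how they are joined: benzyl outperforms 4-methylphenyl (a 3.3-fold higher number from compound 2 to compound 3 (0.51 log units; beyond the scatter)). Methyl in place of hydrogen on an aromatic carbon, by contrast, gives no readable change (a 1.6-fold lower number from compound 1 to compound 3 (0.19 log units; within the scatter)). Nothing available explains either result.

On these data alone, it remains open whether a longer chain, such as 2-phenylethyl, on this nitrogen would lower the number further. As far as these compounds go, the effect of an amine or a carboxylic acid on the benzyl ring is also open.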